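From fluoro to methyl on the aromatic ring

A few compounds are considered here, and "the series" means these few. Any claim that something is new, unique, unknown or untested is made for them only; others in the source may bear on it.

The compounds measured in a functional assay on the whole organism with Mus musculus as the target (a higher number here means that more compound is needed for the effect, a lower number that less compound is needed), are these
compound 1 `Cn1nc(-c2ccc(F)cc2F)n(C)c1=S` gives 2.37 mg/kg
compound 2 `Cn1nc(-c2cccc(C(F)(F)F)c2)n(C)c1=S` gives > 200 mg/kg as a limit of the assay, not a number
compound 3 `Cn1nc(-c2ccc(F)cc2)n(C)c1=S` gives 1 mg/kg

In this assay compound 3 holds the lower of the two actual numbers (1 mg/kg). Its nearest neighbour is compound 1 (2.37 mg/kg). Compound 2 carries trifluoromethyl and gives only a limit (> 200 mg/kg).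

Compound 4 `Cc1ccc(-c2nn(C)c(=S)n2C)cc1` differs from compound 3 by methyl in place of fluoro on an aromatic carbon, para to a group of 8 heavy atoms (methyl in place of fluoro on an aromatic carbon). Among the compounds with values here, no measured step makes this same exchange. The closest evidence is a 2.4-fold lower number from compound 1 to compound 3 (0.37 log units; beyond the scatter) and that change is hydrogen in place of fluoro, so it bears on the new step only loosely. It does show that a single exchange on this ring moved the number by a modest amount. Compound 3 already holds the lowest number, so a modest move toward a higher number is the likelier outcome, although the size remains uncertain. The estimated change is a 4.0-fold higher number from compound 3 to compound 4 (0.60 log units; beyond the scatter) and it is expected to be modest. In this assay the estimate for compound 4 is 4 mg/kg (expected range 0.8 mg/kg to 40 mg/kg).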

Compound 4, dose for half-maximal effect: 4.2 mg/kg
Estimate against measurement, compound 4: 1.1-fold (0.02 log units) below; measured number inside the range.
By their numbers in this assay, from the lowest: compound 3; then compounds 1 and 4 (each within the scatter of the next). At a limit, above all of these: compound 2.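

In this assay, within the data shown here, the exchange at this place gives a 4.2-fold higher number from compound 3 to compound 4 (0.62 log units; beyond the scatter), the first measured step on the aromatic carbon para to a group of 8 heavy atoms, since the earlier step between compounds with numbers changed the ring elsewhere. Fluoro and methyl match in heavy-atom count, and neither brings a hydrogen-bond donor, a hydrogen-bond acceptor or a net charge, yet the step still lies beyond the scatter, so the number at this place depends on which group sits there even when those counts stay the same. The step is modest, and compound 4 still gives an actual number, so this place accepts methyl as well as fluoro without the value reaching a limit of the assay.

The compounds shown leave open how a methoxy group, an amine, a carboxylic acid or a longer chain would behave at this place, and what hydrogen there would give. Compound 2 gives a limit and not a number, and it does not separate the effect of trifluoromethyl from that of its place on the ring: the limit of > 200 mg/kg in this assay, at which 1 of the 4 values shown sits.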